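Series notes: tail replacement on the shared core

The source may report more compounds than this note shows. Statements on the series, on what has been measured and on what is new or still open speak of the compounds shown alone.

Measured so far:
compound 1 `CCC(=O)NCc1ccc(C(=O)Nc2ccc(C)c(Nc3nccc(-c4cccnc4)n3)c2)cc1` — > 10000 nM, a limit
compound 2 `C=CC(=O)NCc1cccc(C(=O)Nc2ccc(C)c(Nc3nccc(-c4cccnc4)n3)c2)c1` — > 10000 nM, a limit
compound 3 `CCC(=O)Nc1cc(C(=O)Nc2ccc(C)c(Nc3nccc(-c4cccnc4)n3)c2)cc(C(F)(F)F)c1` — > 10000 nM, a limit

In an ADME assay on BaF3 cells (Mus musculus) for cytotoxicity, read by CellTiter-Glo and CCK-8 assay, with a stated time of 72 h (on this read-out lower numbers stand for stronger inhibition of growth and higher numbers for weaker inhibition of growth), compound 1 reaches only a limit, not a number. Going by the values given here, compound 2 and compound 3 likewise stop at a limit, so no step between measured compounds can be drawn, and the whole set sits at the limit of > 10000 nM in this assay, at which 3 of the 3 values shown sit. Compound 1 therefore stands at the edge of what this assay resolves, with nothing to rank it against. Compound 4 `Cc1ccc(NC(=O)c2ccc(CN(CCN(C)C)C(=O)CN(C)C)cc2)cc1Nc1nccc(-c2cccnc2)n1` differs from compound 1 by (2-(dimethylamino)ethyl)(((dimethylamino)methyl)carbonyl)amino in place of propanoylamino on a saturated chain carbon bound to an aromatic carbon. Among the compounds with values here, no measured step guides this change, so no shift beyond the scatter is expected in this assay. The expected step is a step that the limit leaves unreadable from compound 1 to compound 4. Compound 4 is estimated at 12000 nM, within 4000 nM to 40000 nM, most likely reported again as a limit.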

Compound 4, concentration for 50% growth inhibition: > 10000 nM
Compound 4 was reported as a limit; the forecaster's own chance of this, stated with the estimate: 75%; the middle value is on the limit's open side.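

Compound 1 and compound 4 both stop at a limit, so no step can be read between them. The compounds shown leave open how these tails on the shared core rank against one another.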